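Chloro for hydrogen on the phenyl of compound 1

The source may hold more compounds than are shown below. What is called first, only, known or untested is meant among the compounds shown, and "the series" means these compounds.

Two members of this series have numbers in a functional assay on COLO 205 cells (Homo sapiens) for inhibition, read by sulforhodamine B assay, with a stated time of 48 h, tested at 10 uM; a lower number here means less inhibition of growth, a higher number more inhibition of growth at the concentration tested. Compound 1 `c1ccc(-c2nc3sc(-c4ccccc4)cn3n2)cc1` gives 5% there, the lowest of the two values at hand. Among the measured compounds shown here, the only other measured member, compound 2 `COc1cc(-c2nc3sc(-c4ccccc4)cn3n2)cc(OC)c1OC`, gives 15% in this assay; the gap between compound 2 and compound 1 is within the usual scatter of repeated measurements, so the two cannot be told apart on these numbers.

Compound 3 `Clc1ccc(-c2cn3nc(-c4ccccc4)nc3s2)cc1` has no value yet in this assay. It differs from compound 1 in one place: chloro in place of hydrogen on an aromatic carbon. Read one bond further out, the phenyl becomes 4-chlorophenyl. For the measured compounds named here, no pair of measured compounds shows what this change does in this assay, so the two values at hand give no lead on its size or direction. With both measured numbers small and indistinguishable, the step of a number 5 percentage points higher from compound 1 to compound 3 (within the scatter) is expected to be small and not beyond the scatter, in either direction. Compound 3 is therefore estimated at 10% in this assay, with a range from 0% to 35%.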

Compound 3, percent growth inhibition at one concentration: 18%
The estimate for compound 3 lay 8 percentage points below the measured number, and the stated range covers the measured number.
By their numbers in this assay, from the lowest: compounds 1, 2 and 3 (each within the scatter of the next, the first and the last beyond it).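

Chloro in place of hydrogen on this aromatic carbon gives the first readable step in the series in this assay: a number 13 percentage points higher from compound 1 to compound 3 (beyond the scatter). The position therefore accepts a chlorine atom with no loss of growth inhibition, and the number moves up by a modest amount, something the two earlier compounds could not show because no single change connected them. This is one step at one position and one concentration, so it gives the direction of this change here but no general rule for the series, and nothing at hand explains why the number rises.

From the compounds shown here alone, it remains open whether the rise is particular to chloro or would also appear with fluoro, bromo, methoxy or an amine on the same carbon. Going by these compounds, it is also open whether chloro would give a step of similar size on the other phenyl or on compound 2, and whether a second chloro on the same ring would add to this one.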